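Propyl for tert-Butyl on the Carbamate: an Expected Response

A few compounds are considered here, and "the series" means these few. Any claim that something is new, unique, unknown or untested is made for them only; others in the source may bear on it.

Compound 1 `CC(C)(C)OC(=O)N1CCC(Oc2cccc3c2ccn3-c2ccc(S(C)(=O)=O)cc2)CC1` gives 28% in a functional assay on CHO-K1 cells with Glucose-dependent insulinotropic receptor (Homo sapiens) as the target, read by a luciferase reporter, with a stated time of 5 h; on this read-out lower numbers stand for smaller maximal responses and higher numbers for larger maximal responses.
Compound 2 `CC(C)OC(=O)N1CCC(Oc2ncnc3c2CCN3c2ccc(-c3nccs3)cc2F)CC1` gives 74% in this assay.
Compound 3 `CC(C)(C)OC(=O)N1CCC(Oc2ncnc3c2CCN3c2ccc(S(C)(=O)=O)cc2F)CC1` gives 139% in this assay.

Among these three, compound 3 stands highest. Its nearest neighbour in value is compound 2, which lies beyond the scatter below it, and compound 1 lies further still below, also beyond the scatter. Neither of these gaps is a single-point change, since compound 2 differs from compound 3 in its carbamate group and in the aryl portion at once, and compound 1 rests on a different core; each pair only shows what its two values show.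

Compound 4 `CCCOC(=O)N1CCC(Oc2ncnc3c2CCN3c2ccc(S(C)(=O)=O)cc2F)CC1` is the one still to be measured. It differs from compound 3 in one place: propyl in place of tert-butyl on an oxygen next to a carbonyl group. Among the compounds with values here, no measured pair isolates this carbamate exchange, so there is no step to lean on. With compound 3 already at the top of the set, the account expects compound 4 to stay in the same region, with a modest fall that may or may not reach beyond the scatter, estimated as a step of a number 24 percentage points lower from compound 3 to compound 4 (beyond the scatter). The estimate for compound 4 in this assay is 115%, with a range from 70% to 150%.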

Compound 4, largest response reached (reported as percent of maximum), in percent of the reference or control that the assay uses: 111%
Estimate against measurement, compound 4: 4 percentage points above, and the stated range covers the measured number.
By their numbers in this assay, from the lowest: compound 1; then compound 2; then compound 4; then compound 3.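

Within the data shown here, the exchange of tert-butyl for propyl on an oxygen next to a carbonyl group is the first change in the set that can be read in one place, and in this assay it gives a number 28 percentage points lower from compound 3 to compound 4 (beyond the scatter) as a modest step that lies beyond the scatter. This shows that the maximal response does answer to the group at this position, yet the group need not be tert-butyl for a high response, since compound 4 still reaches 111% with propyl, which has 3 heavy atoms in place of 4, and with the shared core left unchanged. No measurement shown here explains the step, and this single pair cannot separate the loss of a carbon from the change in the shape of the chain.

As far as these compounds go, whether the response follows chain length remains open, as an ethyl group, a longer butyl chain or a cyclopropylmethyl group on the same oxygen would be needed to show it. From the compounds shown here alone, it is equally open whether the same exchange gives a step of similar size on the core of compound 1 or with the aryl portion of compound 2.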